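Chloro in Place of Hydrogen on the Aromatic Ring

The compounds below may be only part of what the source reports. "The series", "measured", "known", "first", "only" and "open" are said of these compounds alone.

Three compounds have been measured in a functional assay on HeLa cells (Homo sapiens) for antiproliferative activity, read by MTT assay, with a stated time of 72 h; a higher number here means a weaker inhibitor, a lower number a stronger inhibitor:

compound 1, `CCN(CC)C(=S)SCC1=CC(=O)OC1`, gives 21000 nM
compound 2, `Cc1ccc(NC(=S)SCC2=CCOC2=O)cc1`, gives 5440 nM
compound 3, `O=C1OCC=C1CSC(=S)Nc1ccccc1`, gives 111000 nM

Compound 3 stands at the highest of the three numbers, its nearest neighbour being compound 1 and the furthest compound 2; both gaps lie beyond the usual scatter. Among the measured compounds shown here, the step of a 20-fold higher number from compound 2 to compound 3 (1.31 log units; beyond the scatter) is the only single-point change among the measured compounds, and it shows that removing the methyl from the aromatic ring costs a great deal.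

Compound 4, `O=C1OCC=C1CSC(=S)Nc1ccc(Cl)cc1`, differs from compound 3 by chloro in place of hydrogen on an aromatic carbon. This is the same ring carbon that carries the methyl in compound 2, so the measured step bears on it in reverse: placing a group there, rather than removing one, has so far gone with a lower number. Chloro is not methyl, and no measured compound shows chloro on this ring, so the size of the effect is uncertain. Compound 4 is therefore expected to give a lower number than compound 3, by a 7.4-fold lower number from compound 3 to compound 4 (0.87 log units; beyond the scatter), the estimate being 15000 nM with a range from 3000 nM to 70000 nM.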

Compound 4, half-maximal inhibitory concentration: "not active" (no number reported)
Compound 4 has no reported number here, and the estimate cannot be compared.
By their numbers in this assay, from the lowest: compound 2; then compound 1; then compound 3.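

Among the compounds shown here, compound 4 is reported only as "not active", without a number, so no step from compound 3 to compound 4 can be read. The compounds shown leave open how chloro in place of hydrogen on the aromatic ring shifts the antiproliferative reading of compound 3. No data shown here offer an explanation for this result.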